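From fluoro to chloro: one more aromatic swap

The source may report more compounds than this note shows. Statements on the series, on what has been measured and on what is new or still open speak of the compounds shown alone.

Compound 1 `COc1cc(/C=C/C(=O)/C=C(O)/C=C/c2ccc(OC(C)(C)C(=O)Nc3ccc(C#N)c(C(F)(F)F)c3)c(OC)c2)ccc1O`: 55000 nM
Compound 2 `COc1cc(/C=C/C(=O)/C=C(O)/C=C/c2ccc(OC(C)(C)C(=O)Nc3ccc(F)c(C(F)(F)F)c3)c(OC)c2)ccc1O`: 54800 nM

Both compounds were tested in a functional assay on LNCaP cells (Homo sapiens) for cytotoxicity, read by sulforhodamine B assay, with a stated time of 72 h; on this read-out higher numbers stand for weaker inhibition and lower numbers for stronger inhibition. Compound 2 stands level with compound 1: the two numbers lie within the scatter of each other, so the pair cannot be ranked.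

The next structure is compound 3 `COc1cc(/C=C/C(=O)/C=C(O)/C=C/c2ccc(OC(C)(C)C(=O)Nc3ccc(Cl)c(C(F)(F)F)c3)c(OC)c2)ccc1O`, and the change leading to it is chloro in place of fluoro on an aromatic carbon. In words, this is chloro in place of fluoro on an aromatic carbon, ortho to a trifluoromethyl group and para to a large group.

Going by the values given here, only one measured step bears on this change. That step is a 1.0-fold lower number from compound 1 to compound 2 (0.00 log units; within the scatter), with fluoro in place of cyano on the same aromatic carbon, and it stayed within the scatter. A single step involving a different group is thin evidence, but it gives no sign of sensitivity at this carbon. Starting from compound 2 at 54800 nM, no shift beyond the scatter is expected in this assay. The expected change is a 1.1-fold lower number from compound 2 to compound 3 (0.02 log units; within the scatter). For compound 3 the estimated value is 52000 nM, with an expected range from 28000 nM to 95000 nM.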

Compound 3, half-maximal inhibitory concentration: > 100000 nM
Compound 3: no number, only a limit (the forecaster's own chance of this, stated with the estimate: 10%); at least 1.9-fold (0.28 log units) between middle value and limit.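

In this assay compound 3 gives > 100000 nM, which is a limit of the assay and not a number. Measured against that limit, the data show an at least 1.8-fold higher number from compound 2 to compound 3 (0.26 log units; that floor lies within the scatter) and an at least 1.8-fold higher number from compound 1 to compound 3 (0.25 log units; that floor lies within the scatter), so the chloro compound may lie close to the other two or far from them, and its gap to either cannot yet be called real. What is new is modest: with the fluoro and nitrile compounds level, this aromatic carbon ortho to a trifluoromethyl group looked indifferent to the swap, whereas chloro is the one group of the three whose reading has no number, only a limit, and so the question of sensitivity here is reopened rather than settled: the limit of > 100000 nM in this assay, at which 1 of the 3 values shown sits.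

The compounds shown leave open whether any group at this carbon can move the reading beyond the scatter, since a true value for compound 3 is lacking and no step so far is beyond it. A bromo group, a methyl group or a methoxy group on the same carbon would show whether chloro stands alone or belongs to a wider trend.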